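The source may hold more compounds than are shown below. What is called first, only, known or untested is meant among the compounds shown, and "the series" means these compounds.

The series rests on the shared core of compound 1 `COC1=CC(=O)[C@@]2(c3cc(=O)c4ccc(OC)cc4o3)[C@H](C[C@]3(C)[C@@H](C(=O)O)CC=C4[C@H]3CCCC4(C)C)C(C)=CC[C@H]2C1=O` and compound 2 `COC1=CC(=O)[C@@]2(c3cc(=O)c4c(O)cc(O)cc4o3)[C@H](C[C@]3(C)[C@@H](C(=O)O)CC=C4[C@H]3CCCC4(C)C)C(C)=CC[C@H]2C1=O`, which differ only in the groups carried on one aromatic ring. In a functional assay on HepG2 cells (Homo sapiens) for antiproliferative activity, read by sulforhodamine B assay, with a stated time of 72 h (on this read-out lower numbers stand for stronger inhibition of growth and higher numbers for weaker inhibition of growth), compound 1 gives > 10000 nM, a limit of the assay rather than a number. In this assay compound 2 likewise gives > 10000 nM, again a limit and not a number. Compound 2 therefore stands at the edge of what this assay reports, and the limit of > 10000 nM in this assay, at which 2 of the 2 values shown sit, is the whole of the evidence so far on the series. Compound 3 `COC1=CC(=O)[C@@]2(c3cc(=O)c4c(O)cc(OC)cc4o3)[C@H](C[C@]3(C)[C@@H](C(=O)O)CC=C4[C@H]3CCCC4(C)C)C(C)=CC[C@H]2C1=O` is the next member: methyl in place of hydrogen on an oxygen on an aromatic ring. Among the measured compounds shown here, no step between measured compounds is available, and with both measured neighbours sitting at the limit the step is expected to be none beyond the scatter a step that the limit leaves unreadable from compound 2 to compound 3. Compound 3 is accordingly estimated at 15000 nM in this assay, with a range from 5000 nM to 50000 nM, and most likely reported only as a limit.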

Compound 3, concentration for 50% growth inhibition: 8600 nM
Estimate against measurement, compound 3: 1.7-fold (0.24 log units) above, within the range that was stated.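

In this assay, among the compounds shown here, compound 3, with methoxy where compound 2 has hydroxy, is the only one of the three compounds to give a number rather than a limit, so this substitution pattern can now be placed on the scale. Methyl in place of hydrogen on an oxygen on an aromatic ring gives an at least 1.1-fold lower number from compound 2 to compound 3 (0.06 log units; that floor lies within the scatter), and hydroxy in place of hydrogen on an aromatic carbon gives an at least 1.1-fold lower number from compound 1 to compound 3 (0.06 log units; that floor lies within the scatter); each is only a floor, so neither establishes a real gain. The true size of both steps stays unreadable because the two neighbours give only limits: the limit of > 10000 nM in this assay, at which 2 of the 3 values shown sit.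

Open, going by these compounds, is what a longer chain on that oxygen, such as ethoxy, or an amine in place of the hydroxy would do on this ring. Also open, on these data alone, is whether any change here gives a step beyond the scatter in this assay.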